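The compounds below may be only part of what the source reports. "The series", "measured", "known", "first", "only" and "open" are said of these compounds alone.

Compound 3, `CCN(CC)C/C=C/C(=O)Nc1cc2c(N3CCc4ccccc43)ncnc2cc1OC`, carries a methoxy group on its aromatic ring and a diethylaminobutenamide chain on the amide. Among the measured compounds shown here, in a functional assay on PC-3 cells (Homo sapiens) for antiproliferative activity, read by MTT assay, with a stated time of 72 h (on this read-out higher numbers stand for weaker inhibition and lower numbers for stronger inhibition), compound 3 gives 3690 nM, the lowest of the three numbers measured so far. Compound 1, `C=C(C)C(=O)Nc1cc2c(N3CCc4ccccc43)ncnc2cc1O[C@@H]1CCOC1`, gives 4910 nM in this assay, and the two values lie within the scatter of each other. Compound 2, `CC/C=C/C(=O)Nc1cc2c(N3CCc4ccccc43)ncnc2cc1O[C@@H]1CCOC1`, gives 9590 nM, a number beyond the scatter from compound 3. Compounds 1 and 2 differ only in the amide chain, and that change gave a 2.0-fold higher number from compound 1 to compound 2 (0.29 log units; within the scatter).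

Compound 4, `CCN(CC)C/C=C/C(=O)Nc1cc2c(N3CCc4ccccc43)ncnc2cc1O[C@@H]1CCOC1`, differs from compound 3 in one place: oxolan-3-yl in place of methyl on an oxygen on an aromatic ring. For the measured compounds named here, no measured pair varies this oxygen substituent with everything else held fixed, so the step has no direct precedent among the three compounds. Compounds 1 and 2 already carry the oxolanyloxy group, yet their amide chains differ from that of compound 3, so their values cannot be read as the effect of this change alone. The expected step of a 1.1-fold lower number from compound 3 to compound 4 (0.02 log units; within the scatter) is therefore taken as none beyond the scatter. Compound 4 is estimated at 3500 nM in this assay, within a range from 1200 nM to 10000 nM.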

Compound 4, half-maximal inhibitory concentration: 5780 nM
Beside the measured number, compound 4's estimate is 1.7-fold (0.22 log units) below it; low and high end bracket the measured number.
By their numbers in this assay, from the lowest: compounds 3, 1, 4 and 2 (each within the scatter of the next, the first and the last beyond it).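

On the oxygen on the aromatic ring, with the amide chain held fixed, methoxy to (oxolan-3-yl)oxy gives a 1.6-fold higher number from compound 3 to compound 4 (0.19 log units; within the scatter) in this assay, so this position accepts a larger group carrying a ring and a defined stereocentre with no change that stands clear of the scatter. With the (oxolan-3-yl)oxy group kept, the amide chain changes give a 1.7-fold lower number from compound 2 to compound 4 (0.22 log units; within the scatter) and a 1.2-fold higher number from compound 1 to compound 4 (0.07 log units; within the scatter), so diethylamino brings no clear change on this read-out in either comparison. No measurements are available that could explain these small steps.

Still open, as far as these compounds go, is how a piperidine ring in place of diethylamino would read in this assay. Also open, from the compounds shown here alone, are a 2-methoxyethyl group in place of methyl on that oxygen and the opposite configuration of the oxolan-3-yl stereocentre.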